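A few compounds are considered here, and "the series" means these few. Any claim that something is new, unique, unknown or untested is made for them only; others in the source may bear on it.

Series notes. Compound 1 `O=C(/C=C\Nc1cnc2ccccc2c1)c1nc(-c2ccccc2)n2ccccc12` carries a plain phenyl on the shared core; in a functional assay on MDA-MB-231 cells (Homo sapiens) for cytotoxicity, read by MTT assay, with a stated time of 48 h (a higher number here means a weaker inhibitor, a lower number a stronger inhibitor), compound 1 gives 12300 nM. Compound 2 `COc1ccc(N/C=C\C(=O)c2nc(-c3ccc(OC)cc3)n3ccccc23)cc1` carries methoxy groups where compound 1 does not. In this assay compound 2 gives only a limit, > 30000 nM, so no number is known for it. Compound 2 therefore stands at the limit of > 30000 nM in this assay, at which 1 of the 2 values shown sits, and the two measured values allow no more than the statement that compound 1 has a number and compound 2 does not.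

Compound 3 `COc1ccc(N/C=C\C(=O)c2nc(-c3ccccc3)n3ccccc23)cc1` is the compound to be measured next: hydrogen in place of methoxy on an aromatic carbon, so that the ring attached to the core matches that of compound 1 while the methoxyphenyl amine of compound 2 is kept. Among the compounds with values here, no step between two measured compounds of this kind is available, and compound 2 gives only a limit, so the size of the step is uncertain. For compound 3 a value near 20000 nM is estimated, within 8000 nM to 50000 nM. The expected step is an at least 1.5-fold lower number from compound 2 to compound 3 (0.17 log units; that floor lies within the scatter), toward stronger inhibition, with a real chance that this assay again reports only a limit.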

Compound 3, half-maximal inhibitory concentration: 28300 nM
Beside the measured number, compound 3's estimate is 1.4-fold (0.15 log units) below it; measured number inside the range.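

Holding the phenyl on the shared core fixed, the group on the amine nitrogen can now be read for the first time in this assay: 4-methoxyphenyl in place of quinolin-3-yl gives a 2.3-fold higher number from compound 1 to compound 3 (0.36 log units; beyond the scatter) and so moves toward weaker inhibition, a modest step beyond the scatter. Compound 3 also gives the methoxy position on the ring attached to the core a first reading, as the change from 4-methoxyphenyl to phenyl gives an at least 1.0-fold lower number from compound 2 to compound 3 (0.02 log units; that floor lies within the scatter) and that floor lies within the scatter, so no real gain is established. The true size of this step stays open because compound 2 is held only by a limit of the assay, not a number: the limit of > 30000 nM in this assay, at which 1 of the 3 values shown sits.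

The compounds shown leave open whether the methoxy step would read the same with quinolin-3-yl on the amine nitrogen. Also open, going by these compounds, is what a fluorine or a hydroxyl in place of the methoxy on the ring attached to the core would do, or a benzyl group on the amine nitrogen in place of the aromatic groups seen so far.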